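The source may report more compounds than this note shows. Statements on the series, on what has been measured and on what is new or still open speak of the compounds shown alone.

Measured so far in an assay on isolated protein for inhibition of bone morphogenetic protein 1 (Homo sapiens); on this read-out lower numbers stand for stronger inhibition and higher numbers for weaker inhibition:
compound 1 `COc1ccc(S(=O)(=O)N(Cc2ccc(C(C)C)cc2)[C@H](C)C(=O)NO)cc1`, 230 nM
compound 2 `COc1ccc(S(=O)(=O)N(CCn2cccc2)[C@H](C)C(=O)NO)cc1`, 170 nM
compound 3 `COc1ccc(S(=O)(=O)N(Cc2cnc(Cl)s2)[C@H](C)C(=O)NO)cc1`, 180 nM

Compound 1 gives the largest of these three numbers, yet its gaps to compound 3 and to compound 2 both lie within the scatter. The step to compound 4 `COc1ccc(S(=O)(=O)N(Cc2ccc(F)c(F)c2)[C@H](C)C(=O)NO)cc1` is 3,4-difluorophenyl in place of 4-isopropylphenyl on a saturated chain carbon bound to a sulfonamide nitrogen. Two measured steps exchange the same group at the same place: a 1.4-fold lower number from compound 1 to compound 2 (0.13 log units; within the scatter) and a 1.3-fold lower number from compound 1 to compound 3 (0.11 log units; within the scatter). Neither of them moved the number beyond the scatter, so a further exchange at this position is expected to leave this assay essentially unchanged, with no step beyond the scatter in either direction. For compound 4 the expected step is a 1.2-fold lower number from compound 1 to compound 4 (0.06 log units; within the scatter). Compound 4 is therefore estimated at 200 nM, within a range from 100 nM to 450 nM.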

Compound 4, half-maximal inhibitory concentration: 76 nM
Beside the measured number, compound 4's estimate is 2.6-fold (0.42 log units) above it; measured number below the stated range.
By their numbers in this assay, from the lowest: compound 4; then compounds 2, 3 and 1 (each within the scatter of the next).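

Unlike the exchanges among the earlier compounds, the change to 3,4-difluorophenyl on a saturated chain carbon bound to a sulfonamide nitrogen goes beyond the scatter in this assay, with a 3.0-fold lower number from compound 1 to compound 4 (0.48 log units; beyond the scatter) and a 2.4-fold lower number from compound 3 to compound 4 (0.37 log units; beyond the scatter) and also a 2.2-fold lower number from compound 2 to compound 4 (0.35 log units; beyond the scatter) in this read-out. This position therefore does respond to the group it carries, and compound 4 stands apart from the other three compounds. Nothing available explains this difference.

On these data alone, whether the gain needs both fluorines remains open. So does whether a phenyl ring bearing an amine or a carboxylic acid would keep it.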